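One Aryl Swap on Compound 2

The compounds below may be only part of what the source reports. "The series", "measured", "known", "first", "only" and "open" are said of these compounds alone.

Of the compounds shown here, two have so far been read in a functional assay on A375P cells (Homo sapiens) for inhibition, read by MTT assay, with a stated time of 24 h (a lower number here means a stronger inhibitor of growth, a higher number a weaker inhibitor of growth), and only one of them gave a number. Compound 1 (`O=C1CC(c2ccc(NC(=O)Nc3ccc(Cl)c(C(F)(F)F)c3)cc2)=Nc2cn[nH]c2N1`) returned > 30000 nM in this assay and that value is a limit of the assay, not a number. Within the data shown here, compound 2 (`COc1ccc(Cn2ncc3c2NC(=O)CC(c2cccc(NC(=O)Nc4cc(Cl)cc(Cl)c4)c2)=N3)cc1`) gave 780 nM in this assay and so holds the only actual number available, with no second number to rank it against.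

The next compound, compound 3 (`COc1ccc(Cn2ncc3c2NC(=O)CC(c2cccc(NC(=O)Nc4ccc(C(F)(F)F)cc4)c2)=N3)cc1`), differs from compound 2 in one place: 4-(trifluoromethyl)phenyl in place of 3,5-dichlorophenyl on an amide-type nitrogen. Each group is a six-membered aromatic ring of carbon only, and neither carries a net charge.

Among the measured compounds shown here, no measured step between compounds differing in one place is available to size this change. No shift beyond the scatter is expected in this assay in either direction, and this expectation rests on compound 2 at 780 nM alone. The estimated move is a 1.3-fold higher number from compound 2 to compound 3 (0.11 log units; within the scatter) and no larger one is expected. For compound 3 the expected concentration for half-maximal growth inhibition is 1000 nM, with 300 nM to 4000 nM as the estimated range.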

Compound 3, concentration for 50% growth inhibition: 770 nM
The estimate for compound 3 lay 1.3-fold (0.11 log units) above the measured number, within the range that was stated.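

In this assay, among these compounds, placing 4-(trifluoromethyl)phenyl where 3,5-dichlorophenyl stood on the amide-type nitrogen gives a 1.0-fold lower number from compound 2 to compound 3 (0.01 log units; within the scatter), the first step between compounds differing in one place that can be sized here. The two rings carry different groups at different places, yet this read-out does not separate them, so on this shared core the number does not depend on which of these two aryl groups sits on that nitrogen. Nothing available here bears on why the two read alike.

What the compounds shown leave open is how far this indifference extends, for instance whether the number would hold with a pyridine ring, an unsubstituted phenyl, a cyclohexyl group, or a phenyl ring carrying an amine or a carboxylic acid in place of the halogen-bearing groups. Compound 1 gives > 30000 nM, which is a limit of the assay and not a number, and since that compound differs from the others in more than one place, it sizes no single change.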